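This account rests on a few compounds, and the source may have more. Where it says the series, first, only, none or still open, it means among the compounds named here.

Measured compounds:
compound 1 `C=C(Br)C(=O)Nc1ccc2c(c1)/C(=C/c1cccs1)C(=O)N2` gives 1700 nM
compound 2 `C#CC(=O)Nc1ccc2c(c1)/C(=C/c1ccc[nH]1)C(=O)N2` gives 4400 nM
compound 3 `C=C(Br)C(=O)Nc1ccc2c(c1)CC(=O)N2` gives 4500 nM

In a functional assay on HeLa cells (Homo sapiens) for antiproliferative activity, read by MTT assay, with a stated time of 72 h (a lower number here means a stronger inhibitor, a higher number a weaker inhibitor), compound 1 stands lowest of the three numbers; compound 2 and compound 3 each lie beyond the scatter above it, at nearly the same distance from compound 1. Compound 4 `C=C(Br)C(=O)Nc1ccc2c(c1)/C(=C/c1ccsc1)C(=O)N2` has not yet been measured. It differs from compound 1 in one place: thiophen-3-yl in place of thiophen-2-yl on a double-bonded chain carbon bound to a double-bonded ring carbon. Among the compounds with values here, no measured pair shows a step of this kind, so there is nothing to weigh it against. The expected step is small, most likely none beyond the scatter, with a slight rise in the number counted as somewhat more likely than a fall. For compound 4 the estimate is 2200 nM, with a range from 900 nM to 5500 nM. The step this expectation means is a 1.3-fold higher number from compound 1 to compound 4 (0.11 log units; within the scatter).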

Compound 4, half-maximal inhibitory concentration: 3500 nM
For compound 4 the middle estimate is 1.6-fold (0.20 log units) below the measured one; low and high end bracket the measured number.
By their numbers in this assay, from the lowest: compound 1; then compounds 4, 2 and 3 (each within the scatter of the next).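

In this assay, thiophen-3-yl in place of thiophen-2-yl gives a 2.1-fold higher number from compound 1 to compound 4 (0.31 log units; beyond the scatter) with the atoms unchanged, so this position responds to the point of attachment of the thiophene alone. Within the data shown here, this modest step is the only single-place step, so its size stands without a comparison. Nothing at hand accounts for the step.

Open, on these data alone, is whether a phenyl or furan-2-yl group at this place would stay nearer compound 1 or compound 4. Also open, as far as these compounds go, is whether a methyl group on either thiophene would shift the number.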